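Varying the Side Group at the Propargylic Carbon

This account rests on a few compounds, and the source may have more. Where it says the series, first, only, none or still open, it means among the compounds named here.

The three measured compounds share one core and differ only in the group on a saturated chain carbon bound to an oxygen on an unsaturated carbon and a triple-bonded carbon. In a functional assay on SW1573 cells (Homo sapiens) for antiproliferative activity, read by sulforhodamine B assay, with a stated time of 48 h (on this read-out lower numbers stand for stronger inhibition of growth and higher numbers for weaker inhibition of growth), compound 1 `COC(=O)C#CC(O/C=C/C(=O)OC)C(C)c1ccccc1` gives 1200 nM. Compound 2 `CCCCCC(C#CC(=O)OC)O/C=C/C(=O)OC` gives 1700 nM in this assay, and compound 3 `COC(=O)C#CC(O/C=C/C(=O)OC)C1CCCCC1` gives 2100 nM. All three numbers lie within the usual scatter of one another, so compound 3 cannot be set apart from compound 1 or compound 2 on these data.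

Compound 4 `CCC(C)C(C#CC(=O)OC)O/C=C/C(=O)OC` differs from compound 3 in one place: sec-butyl in place of cyclohexyl on a saturated chain carbon bound to an oxygen on an unsaturated carbon and a triple-bonded carbon. Among the measured compounds shown here, the one measured step that bears on this is a 1.2-fold higher number from compound 2 to compound 3 (0.09 log units; within the scatter), where pentyl was exchanged for cyclohexyl at the same place. That exchange of one saturated carbon group for another left the number where it was. The move from cyclohexyl to sec-butyl is of the same kind, a change of the group at the same place, and the data give no reason to expect anything different from it.

Compound 4 is therefore expected to give about 1800 nM in this assay, between 900 nM and 3600 nM. The expected step of a 1.2-fold lower number from compound 3 to compound 4 (0.07 log units; within the scatter) is estimated to stay within the scatter.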

Compound 4, concentration for 50% growth inhibition: 910 nM
The estimate for compound 4 lay 2.0-fold (0.30 log units) above the measured number, within the range that was stated.
By their numbers in this assay, from the lowest: compounds 4, 1, 2 and 3 (each within the scatter of the next, the first and the last beyond it).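

Among the compounds shown here, at the place on a saturated chain carbon bound to an oxygen on an unsaturated carbon and a triple-bonded carbon, the exchange of cyclohexyl for sec-butyl gives the first step in this assay that lies beyond the scatter (a 2.3-fold lower number from compound 3 to compound 4 (0.36 log units; beyond the scatter)), so this place does respond to the group it carries, though modestly. The change cannot be read as a general gain for sec-butyl, since its other two steps stay within the scatter (a 1.9-fold lower number from compound 2 to compound 4 (0.27 log units; within the scatter); a 1.3-fold lower number from compound 1 to compound 4 (0.12 log units; within the scatter)), the latter being ethyl in place of phenyl on a saturated chain carbon bound to two saturated chain carbons; compound 4 is set apart from compound 3 alone. No measurement at hand accounts for the step.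

Going by these compounds, the step from cyclohexyl to sec-butyl changes the ring and the carbon count at once, so which of the two goes with the lower number stays open. On these data alone, all four groups here are built of carbon alone, and how an amine, a hydroxyl or a carboxylic acid at this place would read in this assay also remains open.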